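Compound 4: a new group on a ring nitrogen

This account rests on a few compounds, and the source may have more. Where it says the series, first, only, none or still open, it means among the compounds named here.

In a functional assay on HeLa cells (Homo sapiens) for inhibition, read by CCK-8 assay, with a stated time of 48 h (on this read-out higher numbers stand for weaker inhibition and lower numbers for stronger inhibition), compound 3 `O=C(Nc1ccc([N+](=O)[O-])cc1)N1CCN(S(=O)(=O)c2sccc2-c2ccccc2Oc2ccc(O)c(O)c2)CC1` reports only a limit, > 20000 nM. Compound 2 `COc1ccc(Oc2ccccc2-c2ccsc2S(=O)(=O)N2CCN(C(=O)Nc3ccc([N+](=O)[O-])cc3)CC2)cc1OC` also reports only a limit, > 50000 nM. Going by the values given here, the single measured step, a step that the two limits leave unreadable from compound 2 to compound 3, therefore gives no usable size. Compound 4 `O=S(=O)(c1sccc1-c1ccccc1Oc1ccc(O)c(O)c1)N1CCN(C(=S)Nc2ccc(Cl)cc2)CC1` changes one part of compound 3: a group of 10 heavy atoms (7 carbon, 1 nitrogen, 1 sulfur, 1 chlorine; one six-membered aromatic ring of carbon only) in place of a group of 12 heavy atoms (7 carbon, 2 nitrogen, 3 oxygen; one six-membered aromatic ring of carbon only), on an amine nitrogen in a ring. The entering group also sits on compound 1 `COc1ccc(Oc2ccc([N+](=O)[O-])cc2-c2ccsc2S(=O)(=O)N2CCN(C(=S)Nc3ccc(Cl)cc3)CC2)cc1OC`, which has other differences on the core and reports only a limit, > 50000 nM. All three measured compounds thus stand at limits, the limit of > 20000 nM in this assay, at which 1 of the 3 values shown sits, and (the limit of > 50000 nM in this assay, at which 2 of the 3 values shown sit), and none offers a readable size for this change. No step beyond the usual scatter is expected, and the estimated change is a step that the limit leaves unreadable from compound 3 to compound 4. Compound 4 is expected at 25000 nM, with an estimated range from 8000 nM to 60000 nM.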

Compound 4, half-maximal inhibitory concentration: > 50000 nM
Compound 4: only a limit was reported; the forecaster's own chance of this, stated with the estimate: 65%; middle value at least 2.0-fold (0.30 log units) away from the limit.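

Compound 3 and compound 4 each report only a limit, not a number, so the step between them cannot be read. The compounds shown leave open whether any change gives a measured number in this assay rather than a limit.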